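Ester to hydroxypyrrolidine amide: an open solubility question

This account rests on a few compounds, and the source may have more. Where it says the series, first, only, none or still open, it means among the compounds named here.

Measured so far in a physicochemical assay for solubility, read by HPLC, using the shake flask method, with a stated time of 2 h, at pH 2; on this read-out higher numbers stand for higher solubility and lower numbers for lower solubility:
compound 1 `CS(=O)(=O)c1ccc(-c2cnc(N)c(-c3ccc(N)nc3)n2)cc1` gives 206000 nM
compound 2 `COC(=O)c1ccc(-c2cnc(N)c(-c3ccc(C(F)(F)F)cc3)n2)cc1` gives < 5000 nM, a limit of the assay rather than a number
compound 3 `Nc1ccc(-c2nc(-c3ccc(S(=O)(=O)C4CC4)cc3)cnc2N)cn1` gives 212000 nM

Among the measured compounds shown here, compound 2 is the one measured compound for which this assay reports only a limit, at the limit of < 5000 nM in this assay, at which 1 of the 3 values shown sits. For the measured compounds named here, compound 1 and compound 3 both give numbers, and the single measured step in the set, a 1.0-fold higher number from compound 1 to compound 3 (0.01 log units; within the scatter), concerns a sulfonyl substituent that compound 2 does not carry.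

Compound 4 `Nc1ncc(-c2ccc(C(=O)N3CC[C@@H](O)C3)cc2)nc1-c1ccc(C(F)(F)F)cc1` differs from compound 2 in one place: 3-hydroxypyrrolidin-1-yl in place of methoxy on a carbonyl carbon. Going by the values given here, the change sits on a carbonyl carbon, and none of the measured compounds differ from one another at that carbon, so no measured step bears on it. The set therefore gives no basis for saying how large a step to expect in this assay, nor in which direction, beyond the scatter or not.

With only the limit of compound 2 as a starting point, compound 4 is estimated at 15000 nM, with a range from 4000 nM to 60000 nM. That estimate corresponds to an expected at least 3.0-fold higher number from compound 2 to compound 4 (0.47 log units; beyond the scatter), and it rests on the limit of compound 2 rather than on any measured step.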

Compound 4, solubility: 103000 nM
Beside the measured number, compound 4's estimate is 6.9-fold (0.84 log units) below it, outside the stated range (above it).
By their numbers in this assay, from the lowest: compounds 4, 1 and 3 (each within the scatter of the next, the first and the last beyond it). At a limit, below all of these: compound 2.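

In this assay, among the compounds shown here, 3-hydroxypyrrolidin-1-yl in place of methoxy on a carbonyl carbon gives an at least 20-fold higher number from compound 2 to compound 4 (1.31 log units; beyond the scatter), the only measured step at this carbon. For the compounds shown here, the only other measured step, a 1.0-fold higher number from compound 1 to compound 3 (0.01 log units; within the scatter), concerns a sulfonyl substituent and lies within the scatter, so this change is the one in the set that moves the number beyond it. Compound 2 stands at < 5000 nM, which is a limit of the assay and not a number, and the full size of the step stays unknown because it starts from that limit: the limit of < 5000 nM in this assay, at which 1 of the 4 values shown sits.

The change brings in a five-membered non-aromatic ring, a hydrogen-bond donor and a defined stereocentre all at once, and the compounds shown do not separate these. A plain pyrrolidin-1-yl amide, a dimethylamino amide or a carboxylic acid at the same carbonyl carbon, or the opposite configuration of the hydroxyl-bearing carbon, would be needed to tell which part of 3-hydroxypyrrolidin-1-yl goes with the step.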